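The source may report more compounds than this note shows. Statements on the series, on what has been measured and on what is new or still open speak of the compounds shown alone.

Compound 1 `C=C[C@@](C)(/C=C/c1ccc(O)cc1)CCC=O`: > 36600 nM
Compound 2 `C=C[C@@](C)(/C=C/c1ccc(O)cc1)CC/C=C/C(=O)c1ccccc1`: > 36600 nM

Both values come from a functional assay on SEM cells (Homo sapiens) for cytotoxicity, with a stated time of 72 h; a higher number here means that more compound is needed for the effect, a lower number that less compound is needed. Compound 1 gives > 36600 nM, which is a limit of the assay and not a number. Compound 2 gives > 36600 nM, which is also a limit. Compound 1 therefore stands at the limit of > 36600 nM in this assay, at which 2 of the 2 values shown sit, and these numbers do not separate the two compounds.

The next compound is compound 3 `C=C[C@@](C)(/C=C/c1ccc(O)cc1)CC/C=C(\C)C=O`, which keeps the shared core of compound 1 and changes the end of its chain: 2-formylprop-1-en-1-yl in place of formyl on a saturated chain carbon, three bonds along the chain from two double-bonded chain carbons. In words, 2-formylprop-1-en-1-yl takes the place of formyl on a saturated chain carbon, three bonds along the chain from two double-bonded chain carbons.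

Going by the values given here, no measured step shows what a change of this kind does in this assay. Among the compounds with values here, the only guide is that neither compound tested so far gave a number, so little activity is expected here too, and another limit is the likeliest report. The expected step of an at least 1.1-fold lower number from compound 1 to compound 3 (0.04 log units; that floor lies within the scatter) is small and, if it can be seen at all, runs towards a lower number. The estimate for compound 3 is 33000 nM, with an expected range of 14000 nM to 60000 nM.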

Compound 3, half-maximal effective concentration: > 36600 nM
Compound 3: only a limit was reported; the forecaster's own chance of this, stated with the estimate: 65%; at least 1.1-fold (0.04 log units) between middle value and limit.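

In this assay compound 3 gives > 36600 nM, which is a limit of the assay and not a number. Going by these compounds alone, compound 1 also sits at a limit, so no step from compound 1 to compound 3 can be read. The compounds shown leave open whether any change at the end of the chain would give a measurable number: the limit of > 36600 nM in this assay, at which 3 of the 3 values shown sit.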